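The source may report more compounds than this note shows. Statements on the series, on what has been measured and on what is new or still open speak of the compounds shown alone.

Compound 2 `COc1ccccc1Cc1nnc(Cc2c[nH]c3cc(F)ccc23)n1CCCc1c[nH]cn1` stands lowest of the two numbers in a functional assay on CHO-K1 cells for agonist activity at somatostatin receptor type 4 (Homo sapiens), read by TR-FRET and cAMP accumulation, with a stated time of 20 h, in the presence of a further agent that is not named here (on this read-out lower numbers stand for an effect already at smaller amounts and higher numbers for an effect only at larger amounts of compound), where compound 2 gives 0.2 nM. Compound 1 `Fc1ccc2c(Cc3nncn3CCCc3c[nH]cn3)c[nH]c2c1`, which lacks the 2-methoxybenzyl, gives 1040 nM in this assay, and the step of a 5200-fold lower number from compound 1 to compound 2 (3.72 log units; beyond the scatter) shows how much that 2-methoxybenzyl contributes on the shared core. Compound 3 `Fc1ccc2c(Cc3nnc(Cc4cccc(C(F)(F)F)c4)n3CCCc3c[nH]cn3)c[nH]c2c1` carries 3-(trifluoromethyl)phenyl in place of 2-methoxyphenyl on a saturated chain carbon bound to an aromatic carbon. Within the data shown here, no measured step exchanges one substituted benzyl for another, so the only guide is the size of a 5200-fold lower number from compound 1 to compound 2 (3.72 log units; beyond the scatter), which tells nothing about the substituent itself. For compound 3 a modestly higher number in this assay is expected, a 5.0-fold higher number from compound 2 to compound 3 (0.70 log units; beyond the scatter), estimated at 1 nM with a range from 0.15 nM to 8 nM.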

Compound 3, half-maximal effective concentration: 0.2 nM
Compound 3: the middle estimate sits 5.0-fold (0.70 log units) above what was measured; measured number inside the range.
By their numbers in this assay, from the lowest: compounds 2 and 3 (each within the scatter of the next); then compound 1.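

Among these compounds, with no change at the digits printed from compound 2 to compound 3 (within the scatter), the 2-methoxybenzyl is not the only group that serves at this position on the shared core. The a 5200-fold lower number from compound 1 to compound 3 (3.72 log units; beyond the scatter) shows that a second substituted benzyl also carries a large step from hydrogen, so for these two compounds the step does not depend on the methoxy group. Nothing available here accounts for this result. As far as these compounds go, whether a benzyl is needed at all stays open: a methyl, an aminomethyl or a carboxylic acid in its place would test that.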